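The source may hold more compounds than are shown below. What is called first, only, known or untested is meant among the compounds shown, and "the series" means these compounds.

Compound 1, `COc1ccc(-c2cc(C(C)=O)c3[nH]c(-c4ccccc4)cc3c2)cc1`, gives 87.9% in a functional assay on HeLa cells (Homo sapiens) for cytotoxicity, read by MTT assay, with a stated time of 2 days, tested at 0.1 uM; a higher number here means a weaker effect of the compound at the concentration tested, a lower number a stronger effect.
Compound 2, `COc1ccc(-c2cc(C(C)=O)c3[nH]c(-c4ccc(F)cc4)cc3c2)cc1`, gives 74.5% in this assay.
Compound 3, `CC(=O)c1cc(/C=C/c2ccccc2)cc2cc(-c3ccc(F)cc3)[nH]c12`, gives 82.2% in this assay.

All three are built on a shared framework; how the core of compound 3 differs from the core of compound 1 is not broken down here. Compound 4, `CC(=O)c1cc(/C=C/c2ccc(F)cc2)cc2cc(-c3ccc(F)cc3)[nH]c12`, has not yet been measured. Between compound 1 and compound 2 the change is fluoro in place of hydrogen on an aromatic carbon, and it brought a number 13.4 percentage points lower from compound 1 to compound 2 (beyond the scatter). Between compound 3 and compound 4 the change is fluoro in place of hydrogen on an aromatic carbon. The place of the change is described in the same words both times, so this is the same change carried onto a different core. The cores themselves leave the numbers close together, as a number 7.7 percentage points higher from compound 2 to compound 3 (within the scatter) shows. Compound 4 is therefore expected to move in the same direction as before, because the earlier step gave a number 13.4 percentage points lower from compound 1 to compound 2 (beyond the scatter) on a similar frame. The expected step from compound 3 to compound 4 in this assay is a number 11.2 percentage points lower from compound 3 to compound 4 (beyond the scatter). Compound 4 is estimated at 71%. For compound 4 the expected range runs from 58% to 84%.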

Compound 4, a percentage reported as activity, at one concentration (the size of the read-out at that concentration, not a potency): 72.6%
Compound 4: the middle estimate sits 1.6 percentage points below what was measured, within the range that was stated.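

Set side by side, the two fluoro-for-hydrogen steps in this assay cannot be told apart in size: the same change on two cores in this assay, a number 13.4 percentage points lower (beyond the scatter) from compound 1 to compound 2 and a number 9.6 percentage points lower (within the scatter) from compound 3 to compound 4, 3.8 percentage points apart, within the scatter of two such steps. This fits a change that carries over from one core to the other, but it does not prove it: the new step on its own, a number 9.6 percentage points lower from compound 3 to compound 4 (within the scatter), is no larger than the ordinary spread of repeat measurements, and two cores are too few to set a rule for the series. Exchanging the larger group gives no readable separation either, with 2-(4-fluorophenyl)ethenyl in place of 4-methoxyphenyl giving a number 1.9 percentage points lower from compound 2 to compound 4 (within the scatter).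

The compounds shown leave open whether a different group in the same place, such as chloro, an amine or a carboxylic acid, would act as fluoro does. Each compound is read at a single concentration, so the numbers show only a stronger or weaker effect at that concentration and leave the effect at any other concentration open.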